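The source may report more compounds than this note shows. Statements on the series, on what has been measured and on what is new or still open speak of the compounds shown alone.

Measured so far:
compound 1 `Cc1ccc(OCC(=O)N(Cc2cccs2)c2nccs2)cc1` gives 2240 nM
compound 2 `O=C(COc1ccc2c(c1)CCC2)N(Cc1cccs1)c1ccn[nH]1` gives 0.001 nM

Both compounds were measured in an assay on HEK293 cells for agonist activity at transient receptor potential cation channel subfamily M member 8 (Homo sapiens), read by fluorescence and calcium flux, with a stated time of 15 min; a lower number here means that less compound is needed, a higher number that more compound is needed for the effect. Compound 1 stands at the highest of the two numbers; its nearest neighbour, compound 2, sits at a far lower number, and the gap between the two lies beyond the scatter. Among the measured compounds shown here, the two structures differ in more than one place, so the pair shows only that the two values lie far apart.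

Compound 3 `Cc1ccc(OCC(=O)N(Cc2cccs2)c2cnccn2)cc1` has not yet been measured. It differs from compound 1 in a single place: pyrazin-2-yl in place of 1,3-thiazol-2-yl on an amide-type nitrogen

No step between two measured compounds involves such a change, so the size of the step from compound 1 to compound 3 is not fixed by anything shown. A small step is expected, in either direction, possibly none beyond the scatter; the estimate for a 1.3-fold higher number from compound 1 to compound 3 (0.13 log units; within the scatter) reflects that. Compound 3 is therefore expected to give about 3000 nM, within a range from 700 nM to 12000 nM.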

Compound 3, half-maximal effective concentration: 1240 nM
Compound 3: middle estimate off by 2.4-fold (0.38 log units), on the high side; measured number inside the range.
By their numbers in this assay, from the lowest: compound 2; then compounds 3 and 1 (each within the scatter of the next).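

In this assay, the change on the amide-type nitrogen gives a 1.8-fold lower number from compound 1 to compound 3 (0.26 log units; within the scatter) and so stays within the scatter; compound 1 and compound 3 cannot be told apart. At this position, then, a six-membered aromatic ring with 2 hetero atoms and no sulfur, pyrazin-2-yl, serves as well as the five-membered 1,3-thiazol-2-yl, something the earlier pair could not show because its members differ in more than one place. No measurement is at hand that bears on why the two rings give such similar values.

The compounds shown leave open whether a group of another kind on this nitrogen, such as a phenyl ring or an amine, would keep the value in this range. They also leave open which of the differences between compound 1 and compound 2 accounts for the wide gap between their values.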